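Swapping the piperazine of compound 3 for dimethylamino

This account rests on a few compounds, and the source may have more. Where it says the series, first, only, none or still open, it means among the compounds named here.

Compound 1 `COc1ccc(CNCc2c(OC)cc(Oc3cccc(Nc4ccccc4)c3)cc2OC)cc1` in a functional assay on HT-29 cells (Homo sapiens) for inhibition, read by MTT assay, with a stated time of 72 h (a lower number here means a stronger inhibitor, a higher number a weaker inhibitor), gives 1890 nM
Compound 2 `COc1cc(Oc2cccc(Nc3ccccc3)c2)cc(OC)c1CN[C@H](C)c1ccccc1` in this assay gives 5120 nM
Compound 3 `CCN1CCN(Cc2c(OC)cc(Oc3cccc(Nc4ccccc4)c3)cc2OC)CC1` in this assay gives the limit > 20000 nM

Compound 3 has only a limit, not a number (the limit of > 20000 nM in this assay, at which 1 of the 3 values shown sits). Compound 4 `COc1cc(Oc2cccc(Nc3ccccc3)c2)cc(OC)c1CN(C)C` has not yet been measured. Its structure differs from that of compound 3 in one place (dimethylamino in place of 4-ethylpiperazin-1-yl on a saturated chain carbon bound to an aromatic carbon): dimethylamino in place of 4-ethylpiperazin-1-yl on a saturated chain carbon bound to an aromatic carbon.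

For the measured compounds named here, no measured step makes this exact swap. The closest evidence is an at least 10-fold higher number from compound 1 to compound 3 (1.02 log units; beyond the scatter) and an at least 3.9-fold higher number from compound 2 to compound 3 (0.59 log units; beyond the scatter), both of which replace a benzyl-type amine with 4-ethylpiperazin-1-yl. Compound 4, like compound 3, lacks the 4-methoxybenzyl and 1-phenylethyl groups, so a return to the values of compound 1 or compound 2 is not expected. The estimate is a modest move to a lower number, an at least 1.6-fold lower number from compound 3 to compound 4 (0.22 log units; that floor lies within the scatter), and a result at the limit again would be no surprise. The estimate for compound 4 is 12000 nM (expected range 4500 nM to 30000 nM).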

Compound 4, half-maximal inhibitory concentration: > 20000 nM
Compound 4 was reported as a limit (the forecaster's own chance of this, stated with the estimate: 40%); middle value at least 1.6-fold (0.22 log units) from the limit.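

In this assay compound 4 is reported only as a limit of the assay, not a number, and the step between compound 3 and compound 4 cannot be read: the limit of > 20000 nM in this assay, at which 2 of the 4 values shown sit.

Compound 3 alone could not show whether the bulk of its 4-ethylpiperazin-1-yl group was what mattered, but the much smaller dimethylamino, with no ring, also gives no readable number. Dimethylamino in place of the larger amines gives an at least 10-fold higher number from compound 1 to compound 4 (1.02 log units; beyond the scatter) and an at least 3.9-fold higher number from compound 2 to compound 4 (0.59 log units; beyond the scatter), so among these four compounds only those with an aromatic ring on the amine give a number.

Those two compounds also keep a hydrogen on the amine nitrogen, so the ring and that hydrogen cannot be told apart. A methylamino group, which keeps the hydrogen without the ring, and an N-methylbenzylamino group, which keeps the ring without the hydrogen, would separate them.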